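A few compounds are considered here, and "the series" means these few. Any claim that something is new, unique, unknown or untested is made for them only; others in the source may bear on it.

Measured so far:
Compound 1 `COc1ccc(Nc2nc3cc(-c4ccc5c(ccn5C)c4)ccc3o2)cc1` gives 280 nM in an assay on HEK293 cells for inhibition of Fatty-acid amide hydrolase 1 (Homo sapiens), read by fluorescence; a higher number here means a weaker inhibitor, a lower number a stronger inhibitor.
Compound 2 `Cn1ccc2cc(-c3ccc4oc(N5CCNCC5)nc4c3)ccc21` gives > 1000 nM in this assay; this is a limit of the assay rather than a number.

Compound 2 therefore stands only at a limit. Within the data shown here, the one measured step, an at least 3.5-fold higher number from compound 1 to compound 2 (0.55 log units; beyond the scatter), places it above compound 1, and of the two values shown one sits at the limit of > 1000 nM in this assay, at which 1 of the 2 values shown sits. Compound 3 `Cn1ccc2cc(-c3ccc4oc(N5CCN(c6ccccc6)CC5)nc4c3)ccc21` differs from compound 2 by phenyl in place of hydrogen on an amine nitrogen in a ring. Among the measured compounds shown here, no measured step covers this change directly; the only step in hand, an at least 3.5-fold higher number from compound 1 to compound 2 (0.55 log units; beyond the scatter), concerns the exchange of the whole amine substituent and runs from an aromatic amine toward the weaker compound. Compound 3 restores an aromatic ring, though on a different atom, so a small gain at most is expected, possibly none beyond the scatter. Compound 3 is estimated at 1500 nM, within 300 nM to 8000 nM. For compound 3 this means an expected step that the limit leaves unreadable from compound 2 to compound 3.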

Compound 3, half-maximal inhibitory concentration: 63 nM
Compound 3: middle estimate off by 24-fold (1.38 log units), on the high side, outside the stated range (below it).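

Setting phenyl in place of hydrogen on the amine nitrogen in the ring gives an at least 15-fold lower number from compound 2 to compound 3 (1.20 log units; beyond the scatter) in this assay. This shows that the nitrogen can carry a large group and that the number then falls, which the earlier step, an exchange of the whole amine substituent, could not show. Compound 2 gives > 1000 nM, which is a limit of the assay, so the step is known only as a bound and its full size stays unread: the limit of > 1000 nM in this assay, at which 1 of the 3 values shown sits.

The compounds shown leave open whether the gain needs an aromatic ring on this nitrogen or would also come with a methyl, an acetyl or a benzyl group. They also leave open whether a methoxy or a fluorine on the phenyl would move the number further.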